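Methyl to Methoxy on the Anilide Ring of Compound 2

The source may report more compounds than this note shows. Statements on the series, on what has been measured and on what is new or still open speak of the compounds shown alone.

Three compounds have been tested in an ADME assay on HCT-116 cells (Homo sapiens) for cytotoxicity, read by MTT assay, with a stated time of 72 h; on this read-out lower numbers stand for stronger inhibition and higher numbers for weaker inhibition:
Compound 1 `Cc1ccc(NC(=O)c2cccc(/C=C3\CC(=O)N(c4ccccc4)C3=O)c2)cc1` gives > 100000 nM, which is a limit of the assay.
Compound 2 `CCCCCN1C(=O)C/C(=C\c2cccc(C(=O)Nc3ccc(C)cc3)c2)C1=O` gives > 100000 nM, again a limit.
Compound 3 `Cc1cccc(NC(=O)c2cccc(/C=C3\CC(=O)N(c4ccccc4)C3=O)c2)c1` gives > 100000 nM, also a limit.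

Because all three sit at the limit of > 100000 nM in this assay, at which 3 of the 3 values shown sit, the steps a step that the two limits leave unreadable from compound 1 to compound 2 and a step that the two limits leave unreadable from compound 1 to compound 3 cannot be read. Compound 4 `CCCCCN1C(=O)C/C(=C\c2cccc(C(=O)Nc3ccc(OC)cc3)c2)C1=O` differs from compound 2 by methoxy in place of methyl on an aromatic carbon. No measured step bears on this change, and nothing in the shown values points beyond the scatter in either direction in this assay. Compound 4 is therefore expected to give 150000 nM, in the range 60000 nM to 400000 nM, with the step that the limit leaves unreadable from compound 2 to compound 4 expected to be unreadable as well.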

Compound 4, half-maximal inhibitory concentration: > 100000 nM
Compound 4: no number, only a limit; the forecaster's own chance of this, stated with the estimate: 85%; the middle value does not contradict the limit.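

Compound 2 and compound 4 both give only a limit of the assay, and the step from methyl to methoxy cannot be read. The compounds shown leave open which change to the shared core, if any, would give a real number in this assay rather than a limit.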